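From 2,4,6-trihydroxyphenyl to 2,5-dimethylphenyl: compound 3 to compound 4

The compounds below may be only part of what the source reports. "The series", "measured", "known", "first", "only" and "open" are said of these compounds alone.

In a functional assay on DU-145 cells (Homo sapiens) for inhibition, read by trypan blue exclusion, with a stated time of 96 h (a lower number here means a stronger inhibitor of growth, a higher number a weaker inhibitor of growth), compound 1 (`Cc1ccsc1/C=C(/SCc1ccc(Cl)cc1)C(=O)c1ccc(Cl)cc1`) gives 50000 nM and compound 2 (`COc1ccccc1/C=C(/SCc1ccc(Cl)cc1)C(=O)c1ccc(Cl)cc1`) gives 1000 nM. That pair shows a 50-fold lower number from compound 1 to compound 2 (1.70 log units; beyond the scatter). Compound 3 (`O=C(/C(=C\c1c(O)cc(O)cc1O)SCc1ccc(Cl)cc1)c1ccc(Cl)cc1`) has only a limit, > 100000 nM.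

Compound 4 (`Cc1ccc(C)c(/C=C(/SCc2ccc(Cl)cc2)C(=O)c2ccc(Cl)cc2)c1`) differs from it as follows: 2,5-dimethylphenyl in place of 2,4,6-trihydroxyphenyl on a double-bonded chain carbon bound to a double-bonded chain carbon. Within the data shown here, two measured steps bear on this change: an at least 100-fold higher number from compound 2 to compound 3 (2.00 log units; beyond the scatter) and an at least 2.0-fold higher number from compound 1 to compound 3 (0.30 log units; that floor lies within the scatter). The closer guide is compound 2 at 1000 nM, which also carries a substituted phenyl without the hydroxy groups, although compound 1 at 50000 nM warns of a wide spread.

The expected result is a large fall in the number, an at least 33-fold lower number from compound 3 to compound 4 (1.52 log units; beyond the scatter). For compound 4 the estimated value is 3000 nM, with an expected range from 400 nM to 25000 nM.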

Compound 4, concentration for 50% growth inhibition: 10000 nM
Compound 4: the middle estimate sits 3.3-fold (0.52 log units) below what was measured; low and high end bracket the measured number.
By their numbers in this assay, from the lowest: compound 2; then compound 4; then compound 1. At a limit, above all of these: compound 3.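

Placing 2,5-dimethylphenyl on this double-bonded chain carbon gives an at least 10-fold lower number from compound 3 to compound 4 (1.00 log units; beyond the scatter), which is only a floor, as compound 3 has just a limit: the limit of > 100000 nM in this assay, at which 1 of the 4 values shown sits.

A phenyl group with 0 hydrogen-bond donors can therefore give a measurable number here, though not every such group matches the best value shown. Compound 4 falls in the middle, with a 10-fold higher number from compound 2 to compound 4 (1.00 log units; beyond the scatter) and a 5.0-fold lower number from compound 1 to compound 4 (0.70 log units; beyond the scatter).

The compounds shown leave open whether a phenyl group with a single hydroxy group would behave like 2,4,6-trihydroxyphenyl. On these data alone, how an amine or a carboxylic acid on the phenyl group would fare at this place also stays open.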